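The source may hold more compounds than are shown below. What is called first, only, known or untested is meant among the compounds shown, and "the series" means these compounds.

In a functional assay on UACC-257 cells (Homo sapiens) for cytotoxicity, read by sulforhodamine B assay, with a stated time of 48 h, tested at 0.1 uM (on this read-out lower numbers stand for a stronger effect and higher numbers for a weaker effect at the one concentration tested), compound 1 `COc1cc(-c2cc(/C=C/C(=O)c3ccc(Cl)c(Cl)c3)[nH]n2)cc(OC)c1OC` gives 96%. Compound 2 `COc1ccc(-c2cc(/C=C/C(=O)c3ccc(N)cc3)[nH]n2)cc1OC` gives 90% and compound 3 `COc1ccc(-c2cc(/C=C/C(=O)c3ccc(N)cc3)[nH]n2)cc1` gives 97% in this assay, so compound 1 sits among three numbers that all lie within the scatter of one another. Among the measured compounds shown here, the only single-point step among them, a number 7 percentage points higher from compound 2 to compound 3 (within the scatter), concerns a methoxy group on the core and stays within the scatter.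

Compound 4 `COc1ccc(C(=O)/C=C/c2cc(-c3cc(OC)c(OC)c(OC)c3)n[nH]2)cc1OC` differs from compound 1 by 3,4-dimethoxyphenyl in place of 3,4-dichlorophenyl on a carbonyl carbon. For the measured compounds named here, no measured step changes this part of the molecule, so nothing in the data points to a shift beyond the scatter. Compound 4 is therefore expected to give about 94% in this assay, from 84% to 102%, a step of a number 2 percentage points lower from compound 1 to compound 4 (within the scatter).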

Compound 4, a percentage reported as activity, at one concentration (the size of the read-out at that concentration, not a potency): 89%
Beside the measured number, compound 4's estimate is 5 percentage points above it; the range from low to high includes it.
By their numbers in this assay, from the lowest: compounds 4, 2, 1 and 3 (each within the scatter of the next).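

In this assay the change at this carbonyl carbon, 3,4-dimethoxyphenyl in place of 3,4-dichlorophenyl, gives the first step read at this position, a number 7 percentage points lower from compound 1 to compound 4 (within the scatter) and so shows that this exchange, which brings in two hydrogen-bond acceptors, leaves the read-out within the scatter. No available evidence bears on this result.

On these data alone, whether a carboxylic acid or a longer chain on this carbonyl carbon would move the read-out beyond the scatter remains open. The shown compounds also leave open how the two aryl groups compare at any other concentration.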